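The compounds below may be only part of what the source reports. "The series", "measured", "known", "first", "only" and "open" are said of these compounds alone.

Series notes. Compounds 2 and 3 share the same atoms joined differently; how the two cores differ is not broken down here. Compound 2 `CC1CCN(c2c(S(=O)(=O)c3cccc(Cl)c3)cnc3ccc(Cl)cc23)CC1` and compound 3 `CC1CCN(c2c(S(=O)(=O)c3cccc(Cl)c3)cnc3cc(Cl)ccc23)CC1` each carry 3-chlorophenyl on a sulfonyl sulfur. In an assay on isolated protein for displacement of a labelled ligand from metabotropic glutamate receptor 5 (Homo sapiens), with a stated time of 60 min, tested at 1 uM (a higher number here means more inhibition at the concentration tested (going by the name of the read-out), a lower number less inhibition), compound 2 gives 92% and compound 3 gives 92%; the two stand level at the digits recorded, within the scatter of each other.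

Compound 1 `Cc1ccc(S(=O)(=O)c2cnc3cc(Cl)ccc3c2N2CCC(C)CC2)cc1F` is derived from compound 3 by the change (3-fluoro-4-methylphenyl in place of 3-chlorophenyl on a sulfonyl sulfur). In this assay compound 1 gives 85%, and the step is a number 7 percentage points lower from compound 3 to compound 1 (within the scatter), within the scatter.

Compound 4 `Cc1ccc(S(=O)(=O)c2cnc3ccc(Cl)cc3c2N2CCC(C)CC2)cc1F` is related to compound 2 by the change (3-fluoro-4-methylphenyl in place of 3-chlorophenyl on a sulfonyl sulfur). The place is the same word for word in both pairs, so the change from compound 2 to compound 4 is the same kind of change as that from compound 3 to compound 1, made on the other core. Among the measured compounds shown here, the expected step is a number 7 percentage points lower from compound 2 to compound 4 (within the scatter), resting on the single measured occurrence a number 7 percentage points lower from compound 3 to compound 1 (within the scatter) and on compound 2 sitting at 92%. For compound 4 in this assay the estimate is 85%, with a likely range from 72% to 95%.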

Compound 4, a percentage reported as inhibition, at one concentration (the size of the read-out at that concentration, not a potency): 68%
The estimate for compound 4 lay 17 percentage points above the measured number; measured number outside the range, below it.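

In this assay, 3-fluoro-4-methylphenyl in place of 3-chlorophenyl on a sulfonyl sulfur gives a number 24 percentage points lower from compound 2 to compound 4 (beyond the scatter), so the change does not carry over at one size between these two cores: the same change on two cores in this assay, a number 7 percentage points lower (within the scatter) from compound 3 to compound 1 and a number 24 percentage points lower (beyond the scatter) from compound 2 to compound 4, 17 percentage points apart, beyond the scatter of two such steps. With 3-chlorophenyl the cores stand level, compound 2 giving 92% and compound 3 giving 92%, so here the core makes a visible difference only with the 3-fluoro-4-methylphenyl group, where compound 1 gives 85% and compound 4 gives 68%. This rests on one pair per core at a single concentration, so it shows a dependence on the core for this change alone, gives no potency, and does not explain the gap.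

Going by these compounds, it remains open whether the fluorine or the methyl of the entering group goes with the larger step on the core of compound 2. Also open, on these data alone, is how a 3-methoxyphenyl or 3-cyanophenyl group on the sulfonyl sulfur would behave on the two cores.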